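The compounds below may be only part of what the source reports. "The series", "measured", "known", "first", "only" and "open" are said of these compounds alone.

Working notes on the urea series built on the shared core of compound 1 `COc1cc(NC(C)CCCNC(=O)Nc2cccc(F)c2)c2ncccc2c1`, where only the aryl group on the urea nitrogen is varied. In a functional assay on MIA PaCa-2 cells (Homo sapiens) for inhibition, read by MTT assay, with a stated time of 72 h (on this read-out lower numbers stand for stronger inhibition and higher numbers for weaker inhibition), compound 1 gives 22000 nM; compound 3 `COc1cc(NC(C)CCCNC(=O)Nc2ccc(F)cc2)c2ncccc2c1` gives 21000 nM; and compound 2 `COc1cc(NC(C)CCCNC(=O)Nc2ccc(Br)cc2)c2ncccc2c1` gives 23000 nM. Compound 2 carries the highest number of the three, but its nearest neighbour is compound 1 (a 1.0-fold higher number from compound 1 to compound 2 (0.02 log units; within the scatter)) and its furthest is compound 3 (a 1.1-fold lower number from compound 2 to compound 3 (0.04 log units; within the scatter)), so the three compounds are indistinguishable on this read-out; compound 1 against compound 3 (a 1.0-fold lower number from compound 1 to compound 3 (0.02 log units; within the scatter)) tells the same story.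

Compound 4 `COc1cc(NC(C)CCCNC(=O)Nc2ccc(Cl)cc2)c2ncccc2c1` is the next step from compound 2: chloro in place of bromo on an aromatic carbon. For the measured compounds named here, the one measured step that bears on it is the halogen exchange on the same aromatic carbon, a 1.1-fold lower number from compound 2 to compound 3 (0.04 log units; within the scatter), which stayed within the scatter. No step beyond the scatter is therefore expected in this assay, and compound 4 is expected to show a 1.0-fold lower number from compound 2 to compound 4 (0.02 log units; within the scatter). Compound 4 is estimated at 22000 nM, between 11000 nM and 44000 nM.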

Compound 4, half-maximal inhibitory concentration: 22000 nM
Compound 4: the middle estimate sits on the measured number at the digits printed; low and high end bracket the measured number.
By their numbers in this assay, from the lowest: compounds 3, 1, 4 and 2 (each within the scatter of the next).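

Chloro on this aromatic carbon extends the halogen exchange to a third member, and neither step to it leaves the scatter in this assay (a 1.0-fold lower number from compound 2 to compound 4 (0.02 log units; within the scatter); a 1.0-fold higher number from compound 3 to compound 4 (0.02 log units; within the scatter)). Bromo, chloro and fluoro therefore cannot be told apart here, and the chloro compound adds a comparison with the other ring placement that also stays within the scatter (no change at the digits printed from compound 1 to compound 4 (within the scatter)). No measurement at hand offers an explanation for this flat response.

The compounds shown leave open whether a group other than a halogen on this aromatic carbon, such as an amine, a carboxylic acid or a nitrile, would produce a step beyond the scatter. They also leave open what replacing the whole aryl group on the urea nitrogen with an alkyl chain would do.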